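The source may report more compounds than this note shows. Statements on the series, on what has been measured and on what is new or still open speak of the compounds shown alone.

Measured compounds in an ADME assay on MRC5 cells (Homo sapiens) for cytotoxicity, read by fluorescence and resazurin assay, with a stated time of 3 days; a higher number here means a weaker inhibitor, a lower number a stronger inhibitor:
compound 1, `Cc1cn(C2CCN(Cc3cccc(OC4CCCCC4)c3)CC2)c(=O)[nH]c1=O`: 23600 nM
compound 2, `Cc1cn(C2CCN(Cc3cc(Oc4ccccc4)ccn3)CC2)c(=O)[nH]c1=O`: > 64000 nM, a limit of the assay
compound 3, `Cc1cn(C2CCN(Cc3cccc(Oc4ccccc4)n3)CC2)c(=O)[nH]c1=O`: > 64000 nM, a limit of the assay

In this assay, going by the values given here, compound 1 gives 23600 nM and is the only compound of the three with a number. Compound 2 sits at a limit of the assay, > 64000 nM. Compound 3 also sits at a limit of the assay, > 64000 nM. The position of the set is thus given by the limit of > 64000 nM in this assay, at which 2 of the 3 values shown sit, with compound 1 alone below it. Among the compounds with values here, no two of the measured compounds differ in one place only, so no measured step is available in this assay, and the values of compounds 2 and 3 can only be read as limits beside the number of compound 1.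

Compound 4, `Cc1cn(C2CCN(Cc3cccc(Oc4cccc(Cl)c4)c3)CC2)c(=O)[nH]c1=O`, is not yet measured. Relative to compound 1 the change is 3-chlorophenyl in place of cyclohexyl on an oxygen on an aromatic ring. Within the data shown here, with no measured step to lean on, the step of a 1.3-fold higher number from compound 1 to compound 4 (0.10 log units; within the scatter) is expected to be small, within the scatter or at most a slight move toward weaker inhibition. For compound 4 the estimate in this assay is 30000 nM, with a range from 12000 nM to 75000 nM, and a real chance that only a limit is reported.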

Compound 4, half-maximal inhibitory concentration: 21000 nM
Compound 4: the middle estimate sits 1.4-fold (0.15 log units) above what was measured; low and high end bracket the measured number.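

Going by these compounds alone, replacing cyclohexyl with 3-chlorophenyl on an oxygen on an aromatic ring gives, in this assay, a 1.1-fold lower number from compound 1 to compound 4 (0.05 log units; within the scatter), the first measured step. At this position, a six-membered non-aromatic ring of carbon only and a six-membered aromatic ring carrying chlorine therefore read alike, and compound 4 joins compound 1 as a second compound with a number rather than a limit. Compound 2 and compound 3 remain limits of the assay and not numbers, and no step to either of them can be read: the limit of > 64000 nM in this assay, at which 2 of the 4 values shown sit.

On these data alone, the share of the chlorine itself in this step stays open, as the step exchanges the whole ring and cannot separate the chlorine from the change of ring. Also open, as far as these compounds go, is how this assay reads an amine or a carboxylic acid in place of the chlorine, or a longer alkyl chain on the same oxygen.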